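Swapping one ring substituent at the branch point

The compounds below may be only part of what the source reports. "The series", "measured", "known", "first", "only" and "open" are said of these compounds alone.

Measured so far:
- Compound 1, `N=C(NCCCc1c[nH]cn1)NCCC(c1ccccc1)c1ccccn1`: 97.7 nM
- Compound 2, `N=C(NCCCc1c[nH]cn1)NCCC(c1cccc(C(F)(F)F)c1)c1ccccn1`: 525 nM

These two compounds share the same core and differ only in one ring at the branch point of the chain. In a functional assay on ileum for antagonist activity at histamine H1 receptor (Cavia porcellus) (a higher number here means weaker binding, a lower number tighter binding), compound 2 gives 525 nM, the higher of the two numbers; compound 1 gives 97.7 nM. For the measured compounds named here, the one measured step, a 5.4-fold higher number from compound 1 to compound 2 (0.73 log units; beyond the scatter), shows that adding a trifluoromethyl group there weakened binding.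

Compound 3, `N=C(NCCCc1c[nH]cn1)NCCC(c1ccccn1)c1ccccc1F`, has not yet been measured. The change from compound 2 is 2-fluorophenyl in place of 3-(trifluoromethyl)phenyl on a saturated chain carbon bound to an aromatic carbon and a saturated chain carbon. Going by the values given here, the only step that bears on this change is a 5.4-fold higher number from compound 1 to compound 2 (0.73 log units; beyond the scatter), which went in the weakening direction when a substituent was added to the plain ring; here a smaller group replaces the larger one. The expectation is therefore a move back towards the number of compound 1, estimated as a 3.3-fold lower number from compound 2 to compound 3 (0.52 log units; beyond the scatter) in this assay. For compound 3 the estimate in this assay is 160 nM, with a range from 60 nM to 450 nM.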

Compound 3, dissociation constant: 437 nM
The estimate for compound 3 lay 2.7-fold (0.44 log units) below the measured number, and the stated range covers the measured number.
By their numbers in this assay, from the lowest: compound 1; then compounds 3 and 2 (each within the scatter of the next).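

In this assay, 2-fluorophenyl in place of 3-(trifluoromethyl)phenyl gives a 1.2-fold lower number from compound 2 to compound 3 (0.08 log units; within the scatter), so having fewer heavy atoms in the group did not bring the number back towards that of compound 1. Fluoro in place of hydrogen on an aromatic carbon gives a 4.5-fold higher number from compound 1 to compound 3 (0.65 log units; beyond the scatter), which shows that a single fluorine on the plain ring is enough to weaken binding beyond the scatter, and among these three compounds both substituted rings give higher numbers than the plain one. No measurement here explains why the two substituted rings sit within the scatter of each other.

Compounds 2 and 3 differ in both the group and where it sits on the ring, so these compounds cannot separate those two effects. Going by these compounds, whether a hydroxyl or an amine on this ring would also weaken binding remains open.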